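A phenyl group grows out of the ethoxy chain

The compounds below may be only part of what the source reports. "The series", "measured", "known", "first", "only" and "open" are said of these compounds alone.

In an assay on CHO cells for displacement of a labelled ligand from melatonin receptor type 1A (Homo sapiens), read by scintillation counting, with a stated time of 60 min (on this read-out lower numbers stand for stronger inhibition and higher numbers for weaker inhibition), compound 3 `CCOc1ccc(OC)cc1CCCNC(C)=O` gives 183 nM, the second highest of the three numbers: compound 1 `COc1cccc(CCCNC(C)=O)c1` gives 23.3 nM, and compound 2 `CCCC(=O)NCCCc1cc(OC)ccc1OCc1ccccc1` gives 1170 nM. Compound 4 `COc1ccc(OCCc2ccccc2)c(CCCNC(C)=O)c1` carries phenyl in place of hydrogen on a saturated chain carbon, two bonds along the chain from an oxygen on an aromatic ring. Within the data shown here, the one measured step that touches this part of the core, a 7.9-fold higher number from compound 1 to compound 3 (0.90 log units; beyond the scatter), shows that adding an ethoxy group to the bare aromatic carbon already weakens binding. Among the measured compounds shown here, compound 2, with a benzyloxy chain and a longer amide, sits higher still, though it differs in two places and no single step is known for it. A further move in the same direction is therefore expected, a 2.7-fold higher number from compound 3 to compound 4 (0.44 log units; beyond the scatter), and compound 4 is estimated at 500 nM, within 150 nM to 1800 nM.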

Compound 4, inhibition constant: 2930 nM
For compound 4 the middle estimate is 5.9-fold (0.77 log units) below the measured one; measured number above the stated range.
By their numbers in this assay, from the lowest: compound 1; then compound 3; then compound 2; then compound 4.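

In this assay, the change from ethyl to phenethyl brings a 16-fold higher number from compound 3 to compound 4 (1.20 log units; beyond the scatter), so a phenyl on this saturated chain carbon carries a large cost in binding. Together with a 7.9-fold higher number from compound 1 to compound 3 (0.90 log units; beyond the scatter), this makes two steps of growth at this part of the core, and both raise the number. Nothing measured here explains the rise.

The compounds shown leave open whether a propyl chain, with no ring at its end, would raise the number as well. They also leave open how a pyridine ring in place of the phenyl would read.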